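Hydrazone aryl swap on a shared core, ahead of measurement

The source may report more compounds than this note shows. Statements on the series, on what has been measured and on what is new or still open speak of the compounds shown alone.

Compound 1 `Cc1c(C(=O)N/N=C\c2ccc(O)c(O)c2O)oc2cccc(O)c12`: 18100 nM in a functional assay on MGC-803 cells (Homo sapiens) for inhibition, read by MTT assay; on this read-out lower numbers stand for stronger inhibition and higher numbers for weaker inhibition
Compound 2 `Cc1c(C(=O)N/N=C\c2c(O)cccc2F)oc2cccc(O)c12`: 10800 nM in this assay

Of the compounds shown here, two on the shared core have been measured so far. Compound 2 gives the value 10800 nM, and compound 1 gives 18100 nM; the gap between these two numbers lies within the usual scatter of repeated measurements, so the data do not separate them. Going by the values given here, no pair differing in a single place has been measured, so there is no measured step to lean on.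

Compound 3 `Cc1c(C(=O)N/N=C\c2ccc(Br)cc2O)oc2cccc(O)c12` is the next one to be tested. It differs from compound 2 in one place: 4-bromo-2-hydroxyphenyl in place of 2-fluoro-6-hydroxyphenyl on a carbon with a double bond to nitrogen. Among the compounds with values here, with no measured step for a change of this kind, the expectation is that the step of a 1.1-fold lower number from compound 2 to compound 3 (0.03 log units; within the scatter) is none beyond the scatter, in either direction. Compound 3 is therefore estimated at 10000 nM, with a range from 3500 nM to 30000 nM, resting only on the value of compound 2 at 10800 nM.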

Compound 3, half-maximal inhibitory concentration: 5460 nM
The estimate for compound 3 lay 1.8-fold (0.26 log units) above the measured number; low and high end bracket the measured number.
By their numbers in this assay, from the lowest: compounds 3, 2 and 1 (each within the scatter of the next, the first and the last beyond it).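

In this assay, going by these compounds alone, the first measured step at this position, a 2.0-fold lower number from compound 2 to compound 3 (0.30 log units; within the scatter), shows that 4-bromo-2-hydroxyphenyl can replace 2-fluoro-6-hydroxyphenyl on a carbon with a double bond to nitrogen without a shift beyond the scatter, although the halogen and its place on the ring both differ. The new value also gives the first separation in the series: compound 1 at 18100 nM and compound 3 at 5460 nM lie beyond the scatter of each other, so the choice of aryl group at this position can register in this assay, even though neighbouring values in the series cannot be told apart. There is no supporting evidence that could account for these numbers.

Because the halogen and its place on the ring change together between compound 2 and compound 3, the compounds shown leave open whether either change alone would matter. They also leave open how an amine, a carboxylic acid or a methoxy group on this aryl ring would read, and whether any group here could move the value further than the span seen so far.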